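Ring-nitrogen thiourea on a fused thiophene amide scaffold

A few compounds are considered here, and "the series" means these few. Any claim that something is new, unique, unknown or untested is made for them only; others in the source may bear on it.

Measured compounds:
compound 1 `NC(=O)c1c(NC(=O)c2ccccc2Cl)sc2c1CCNC2`, 45000 nM
compound 2 `NC(=O)c1c(NC(=O)c2ccccc2Cl)sc2c1CCN(C(=S)Nc1ccccc1C(F)(F)F)C2`, 26700 nM

In a functional assay on HeLa cells (Homo sapiens) for antiproliferative activity, with a stated time of 24 h (on this read-out higher numbers stand for weaker inhibition and lower numbers for stronger inhibition), compound 1 gives 45000 nM, the higher of the two numbers; compound 2 gives 26700 nM, and the two values lie within the usual scatter of each other. Compound 3 `CSc1ccccc1NC(=S)N1CCc2c(sc(NC(=O)c3ccccc3Cl)c2C(N)=O)C1` carries a change on the shared core: a group of 11 heavy atoms (8 carbon, 1 nitrogen, 2 sulfur; one six-membered aromatic ring of carbon only) in place of a hydrogen atom, on an amine nitrogen in a ring. Within the data shown here, the one comparison available, compound 2 against compound 1, shows no step beyond the scatter for a related substituent at this place, so the expected step of a 1.6-fold lower number from compound 1 to compound 3 (0.21 log units; within the scatter) is none beyond the scatter. In this assay compound 3 is estimated at 28000 nM, with a range from 9000 nM to 90000 nM.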

Compound 3, half-maximal inhibitory concentration: 43600 nM
For compound 3 the middle estimate is 1.6-fold (0.19 log units) below the measured one, and the stated range covers the measured number.
By their numbers in this assay, from the lowest: compounds 2, 3 and 1 (each within the scatter of the next).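

In this assay, a second thiourea-linked aromatic group on the amine nitrogen in a ring again gives no step beyond the scatter: a 1.0-fold lower number from compound 1 to compound 3 (0.01 log units; within the scatter). Methylsulfanyl in place of trifluoromethyl on an aromatic carbon gives a 1.6-fold higher number from compound 2 to compound 3 (0.21 log units; within the scatter), so these two substituents cannot be told apart in this assay. No evidence is available that bears on these results. The compounds shown leave open whether an amine or a carboxylic acid on that aromatic ring, or an acetyl group in place of the thiourea on the amine nitrogen, would give a step beyond the scatter.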